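Swapping an Amide for a Sulfonamide on a Weak Scaffold

The compounds below may be only part of what the source reports. "The series", "measured", "known", "first", "only" and "open" are said of these compounds alone.

Measured so far:
compound 1 `CCCCN1CCc2nc(C#Cc3ccccc3)sc2C1`, > 10000 nM
compound 2 `O=C(C1CCOCC1)N1CCc2nc(C#Cc3ccccc3)sc2C1`, > 10000 nM

In an assay on HEK293 cells for negative allosteric modulation of metabotropic glutamate receptor 5 (Homo sapiens), read by FLIPR, with a stated time of 1 h (a lower number here means a stronger inhibitor, a higher number a weaker inhibitor), compound 1 reaches only the limit of the test, > 10000 nM. In this assay compound 2 likewise gives only a limit, > 10000 nM. The step that the two limits leave unreadable from compound 1 to compound 2 therefore cannot be read, since (the limit of > 10000 nM in this assay, at which 2 of the 2 values shown sit). Compound 2 thus stands at the limit, and no number places it above or below compound 1.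

Compound 3 `CC(C)S(=O)(=O)N1CCc2nc(C#Cc3ccccc3)sc2C1` differs from compound 2 by one change: isopropylsulfonyl in place of (oxan-4-yl)carbonyl on an amine nitrogen in a ring. Among the compounds with values here, the only measured step, from compound 1 to compound 2, is unreadable, so no size or direction can be taken from it for this assay; both measured compounds sit at the limit. On that basis compound 3 is expected to remain near the limit, an estimated 8000 nM (range 1500 nM to 30000 nM), which means an expected step of an at least 1.2-fold lower number from compound 2 to compound 3 (0.09 log units; that floor lies within the scatter).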

Compound 3, half-maximal inhibitory concentration: 11 nM
The estimate for compound 3 lay 730-fold (2.86 log units) above the measured number; measured number below the stated range.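

Among these three compounds, the group on the amine nitrogen in the ring separates a clear reading in this assay from no reading at all, so the shared core is not inactive in itself. Isopropylsulfonyl in place of (oxan-4-yl)carbonyl gives an at least 900-fold lower number from compound 2 to compound 3 (2.95 log units; beyond the scatter), and isopropylsulfonyl in place of butyl gives an at least 900-fold lower number from compound 1 to compound 3 (2.95 log units; beyond the scatter). Both sizes are floors rather than exact figures, since compound 1 and compound 2 each stop at a limit of the test: the limit of > 10000 nM in this assay, at which 2 of the 3 values shown sit.

The compounds shown do not separate the sulfonyl link from the isopropyl group it carries, and an isobutyryl group, which puts isopropyl on a carbonyl, would bear on that question. As far as these compounds go, how much room this position allows also stays open, and methylsulfonyl and phenylsulfonyl groups would begin to answer it.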